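Compound 2 to compound 4: swapping the oxygen substituent

A few compounds are considered here, and "the series" means these few. Any claim that something is new, unique, unknown or untested is made for them only; others in the source may bear on it.

In a functional assay on A-375 cells (Homo sapiens) for cytotoxicity, read by MTT assay (on this read-out lower numbers stand for stronger inhibition and higher numbers for weaker inhibition), the series stands as follows:
- compound 1 `C#CCOc1cc(/C=C/C(=O)c2ccc(OC)c3c2OC(C)(C)C=C3)ccc1OC` gives > 10000 nM as a limit of the assay
- compound 2 `COc1ccc(/C=C/C(=O)c2ccc(OC)c3c2OC(C)(C)C=C3)cc1OCCCN(C)C` gives 4100 nM
- compound 3 `C=CC(=O)Oc1cc(/C=C/C(=O)c2ccc(OC)c3c2OC(C)(C)C=C3)ccc1OC` gives 390 nM

Compound 2 holds the higher of the two actual numbers, and compound 3 is its nearest neighbour. The next compound is compound 4 `COc1ccc(/C=C/C(=O)c2ccc(OC)c3c2OC(C)(C)C=C3)cc1OC(=O)CCl`, not yet measured. It differs from compound 2 by (chloromethyl)carbonyl in place of 3-(dimethylamino)propyl on an oxygen on an aromatic ring.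

The closest measured precedent is the vinylcarbonyl change on the same oxygen, which gave an 11-fold lower number from compound 2 to compound 3 (1.02 log units; beyond the scatter) as its step. The same group also gave a large change against propargyl (an at least 25-fold lower number from compound 1 to compound 3 (1.40 log units; beyond the scatter)). By contrast, the change between the two ethers was smaller (an at least 2.4-fold lower number from compound 1 to compound 2 (0.38 log units; beyond the scatter)).

Going by the values given here, no compound with (chloromethyl)carbonyl has been measured, so a wide range is kept. In this assay a large step to lower numbers is expected, estimated as a 5.9-fold lower number from compound 2 to compound 4 (0.77 log units; beyond the scatter) here. The estimated value for compound 4 is 700 nM (expected range 150 nM to 3000 nM).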

Compound 4, half-maximal inhibitory concentration: 450 nM
The estimate for compound 4 lay 1.6-fold (0.19 log units) above the measured number, within the range that was stated.
By their numbers in this assay, from the lowest: compounds 3 and 4 (each within the scatter of the next); then compound 2. At a limit, above all of these: compound 1.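

Compound 4 shows that the fall in number on this oxygen on an aromatic ring does not depend on the vinyl group: in this assay there is a 9.1-fold lower number from compound 2 to compound 4 (0.96 log units; beyond the scatter), while chloromethyl in place of vinyl on the carbonyl carbon gives a 1.2-fold higher number from compound 3 to compound 4 (0.06 log units; within the scatter), so these two compounds cannot be ordered. Against the propargyl ether, the step is an at least 22-fold lower number from compound 1 to compound 4 (1.34 log units; beyond the scatter). That step starts from a limit and not a number, the one held by compound 1: the limit of > 10000 nM in this assay, at which 1 of the 4 values shown sits.

The compounds shown leave open whether the carbonyl alone carries the step, or whether the vinyl and chloromethyl groups each contribute. A plain acetyl group on the same oxygen, or an amide linked through nitrogen instead of this oxygen, would separate these readings.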